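This account rests on a few compounds, and the source may have more. Where it says the series, first, only, none or still open, it means among the compounds named here.

The measured compounds in an ADME assay on HEK293 cells (Homo sapiens) for cytotoxicity, read by sulforhodamine B assay, with a stated time of 48 h, tested at 10 uM; a lower number here means less inhibition, a higher number more inhibition at the concentration tested (going by the name of the read-out):

compound 1 `COc1nc2ccc(Br)cc2cc1C(c1ccccc1)n1cc(C2CC2)nn1`, which gives 8.22%;
compound 2 `COc1nc2ccc(Br)cc2cc1C(c1ccccc1)n1cc(-c2ccc(Br)cc2)nn1`, which gives 6.28%;
compound 3 `COc1nc2ccc(Br)cc2cc1C(c1ccccc1)n1cc(-c2cccc(F)c2)nn1`, which gives 6.84%.

All three numbers are low, meaning little inhibition of the cells at the tested concentration. Compound 3 stands second highest of the three, but only nominally: its nearest neighbour is compound 2 (a number 0.6 percentage points higher from compound 2 to compound 3 (within the scatter)) and the furthest is compound 1 (a number 1.4 percentage points lower from compound 1 to compound 3 (within the scatter)), both within the scatter, so the three cannot be told apart.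

Compound 4 `CCCCCCCCc1cn(C(c2ccccc2)c2cc3cc(Br)ccc3nc2OC)nn1` differs from compound 3 in a single place: octyl in place of 3-fluorophenyl on an aromatic carbon. The group that leaves is the 3-fluorophenyl, and what enters is an octyl chain, on the same aromatic carbon of the five-membered aromatic ring with three nitrogen.

The measured steps all concern this same position: a number 1.9 percentage points lower from compound 1 to compound 2 (within the scatter), a number 1.4 percentage points lower from compound 1 to compound 3 (within the scatter) and a number 0.6 percentage points higher from compound 2 to compound 3 (within the scatter). Each of them stays within the scatter, whether a cyclopropyl, a 4-bromophenyl or a 3-fluorophenyl sits there. Among the compounds with values here, an octyl chain at this position has no measured precedent, so the expectation rests on the observation that every exchange at this position so far has left the number level, without any step beyond the scatter. A step of no more than the scatter is therefore expected in this assay, in no particular direction.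

Compound 4 is expected to give about 8%, within a range from 0% to 22%. This amounts to an expected step of a number 1.2 percentage points higher from compound 3 to compound 4 (within the scatter).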

Compound 4, a percentage reported as inhibition, at one concentration (the size of the read-out at that concentration, not a potency): 14.6%
The estimate for compound 4 lay 6.6 percentage points below the measured number; the measured number falls inside the stated range.
By their numbers in this assay, from the lowest: compounds 2, 3, 1 and 4 (each within the scatter of the next).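

In this assay, an octyl chain on this aromatic carbon gives a number 7.8 percentage points higher from compound 3 to compound 4 (within the scatter) and a number 8.3 percentage points higher from compound 2 to compound 4 (within the scatter) and also a number 6.4 percentage points higher from compound 1 to compound 4 (within the scatter) without any of these three steps passing beyond the usual variation between repeats. This extends the earlier picture, in which every group at this position carried a ring: an open chain with no ring also leaves compound 4 impossible to tell apart from compound 1, compound 2 and compound 3, so all four compounds share the same level of cell inhibition within the scatter. The steps to compound 4 are larger than those among the earlier three, but that size alone does not establish a real difference, and nothing measured here offers a reason for it.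

The compounds shown leave open whether a longer chain, or a shorter one such as butyl, would give a step beyond the scatter at this position. They also leave open what a chain ending in an amine or a carboxylic acid would do to the number in this assay on these cells.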